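Replacing the chloro of compound 1 with an amino ester

The source may hold more compounds than are shown below. What is called first, only, known or untested is meant among the compounds shown, and "the series" means these compounds.

The measured compounds and their values:
Compound 1 `COc1cc(-c2nc3ccccc3s2)ccc1OCC(=O)NNC(=O)CCl` gives 2890 nM in a functional assay on HepG2 cells (Homo sapiens) for inhibition, read by MTT assay, with a stated time of 3 days; on this read-out higher numbers stand for weaker inhibition and lower numbers for stronger inhibition.
Compound 2 `COc1cc(-c2nc3ccccc3s2)ccc1OCC(=O)NNC(O)CN(C)CC(=O)O` gives 3030 nM.
Compound 3 `COc1cc(-c2nc3ccccc3s2)ccc1OCC(=O)NNC(=O)CN(C(C)=O)[C@@H](CS)C(=O)O` gives 3420 nM.

Compound 1 has the lowest number of the three, yet the steps of a 1.0-fold higher number from compound 1 to compound 2 (0.02 log units; within the scatter) and a 1.2-fold higher number from compound 1 to compound 3 (0.07 log units; within the scatter) both lie within the scatter, so the three compounds cannot be ordered. Compound 4 `CCOC(=O)CN(C)CC(=O)NNC(=O)COc1ccc(-c2nc3ccccc3s2)cc1OC` differs from compound 1 by ((ethoxycarbonyl)methyl)(methyl)amino in place of chloro on a saturated chain carbon bound to a carbonyl carbon. Both measured steps from compound 1 also swapped the chloro at the same place for a larger group, and neither moved the number beyond the scatter. No step beyond the scatter in this assay is therefore expected here either. Compound 4 is estimated at 3000 nM, with a range from 1500 nM to 6000 nM, an expected step of a 1.0-fold higher number from compound 1 to compound 4 (0.02 log units; within the scatter).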

Compound 4, half-maximal inhibitory concentration: 3180 nM
The estimate for compound 4 lay 1.1-fold (0.03 log units) below the measured number, within the range that was stated.
By their numbers in this assay, from the lowest: compounds 1, 2, 4 and 3 (each within the scatter of the next).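

In this assay, the largest group yet tried here, ((ethoxycarbonyl)methyl)(methyl)amino, replaces chloro with a 1.1-fold higher number from compound 1 to compound 4 (0.04 log units; within the scatter), so an ethyl ester on this chain also leaves the number within the scatter. The chloro is therefore not required for the reading in this small set. Compared with the carboxy-bearing groups, the ester gives a 1.1-fold lower number from compound 3 to compound 4 (0.03 log units; within the scatter) and a 1.0-fold higher number from compound 2 to compound 4 (0.02 log units; within the scatter), so ester and free acid cannot be told apart here.

As far as these compounds go, whether a morpholine ring or a longer chain ending in a primary amine would move the number remains open. No measurement at hand explains why these changes leave the number within the scatter.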